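A few compounds are considered here, and "the series" means these few. Any claim that something is new, unique, unknown or untested is made for them only; others in the source may bear on it.

Working notes on the series, in which the group on a carbon with a double bond to nitrogen varies around the shared core. In a functional assay on PC-3 cells (Homo sapiens) for inhibition, read by MTT assay (a lower number here means a stronger inhibitor, a higher number a weaker inhibitor), compound 1 `COc1c(N2CCN(C)CC2)c(F)cc2c(=O)c(C(=O)N/N=C\c3cc(Br)ccc3O)cn(C3CC3)c12` gives 12 ug/mL and compound 2 `COc1c(N2CCN(C)CC2)c(F)cc2c(=O)c(C(=O)N/N=C\c3ccccc3)cn(C3CC3)c12` gives 16.3 ug/mL. These two values lie within the scatter of each other, so compound 2 has no distinct standing in this pair.

The next change leads to compound 3 `COc1cc(/C=N\NC(=O)c2cn(C3CC3)c3c(OC)c(N4CCN(C)CC4)c(F)cc3c2=O)ccc1O`, not yet measured in this assay: 4-hydroxy-3-methoxyphenyl in place of phenyl on a carbon with a double bond to nitrogen. In words, 4-hydroxy-3-methoxyphenyl stands in place of phenyl on a carbon with a double bond to nitrogen.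

Within the data shown here, only one measured step bears on this change: a 1.4-fold higher number from compound 1 to compound 2 (0.13 log units; within the scatter). Among the measured compounds shown here, that step exchanges 5-bromo-2-hydroxyphenyl for phenyl at the same place, so it is only a loose guide, and no measured compound carries the entering group. For the measured compounds named here, with compound 1 to compound 2 as the sole precedent at a 1.4-fold higher number from compound 1 to compound 2 (0.13 log units; within the scatter), no shift beyond the scatter is expected.

The expected step is a 1.2-fold lower number from compound 2 to compound 3 (0.07 log units; within the scatter).

For compound 3 the estimated value is 14 ug/mL, with an expected range from 7 ug/mL to 28 ug/mL.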

Compound 3, half-maximal inhibitory concentration: 14.8 ug/mL
For compound 3 the middle estimate is 1.1-fold (0.02 log units) below the measured one; measured number inside the range.
By their numbers in this assay, from the lowest: compounds 1, 3 and 2 (each within the scatter of the next).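

In this assay, 4-hydroxy-3-methoxyphenyl on a carbon with a double bond to nitrogen gives a 1.1-fold lower number from compound 2 to compound 3 (0.04 log units; within the scatter) when it stands in place of phenyl, and a 1.2-fold higher number from compound 1 to compound 3 (0.09 log units; within the scatter) when it stands in place of 5-bromo-2-hydroxyphenyl. The three groups now tested at this place cannot be told apart in this readout, and the oxygen atoms, hydrogen-bond donor and hydrogen-bond acceptors that 4-hydroxy-3-methoxyphenyl brings relative to phenyl produce no step beyond the scatter. The earlier pair offered only one such comparison, whereas all three pairs among the listed compounds now lie within the scatter, and no other information on these groups bears on this result.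

From the compounds shown here alone, all three groups are six-membered aromatic rings of carbon only, so it remains open whether a pyridyl ring, a saturated cyclohexyl ring or a short alkyl chain on this carbon would separate from them. Also open, going by these compounds, is whether a phenyl ring carrying a dimethylamino group or a carboxylic acid would move the number beyond the scatter in this assay.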